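Chloro to methyl on the central ring: tolerability check

The source may hold more compounds than are shown below. What is called first, only, known or untested is meant among the compounds shown, and "the series" means these compounds.

Compound 1 `Cc1cc(/C=C/C#N)cc(Oc2cc(Nc3ncnc(C4CC4)n3)ccc2Cl)c1` is the less tolerated of the two measured compounds in an ADME assay on MT2 cells (Homo sapiens) for inhibition, read by MTT assay (a higher number here means that more compound is tolerated, a lower number that less compound is tolerated), where compound 1 gives 1800 nM. Compound 2 `COc1ccnc(Nc2ccc(Cl)c(Oc3ccccc3)c2)n1` stands well apart in this assay, where compound 2 gives 38000 nM, a gap that lies beyond the usual scatter, so compound 1 holds the lowest half-maximal cytotoxic concentration in the set. Within the data shown here, no single-change step between measured compounds is available, so nothing has yet been recorded on how a change on the aromatic carbon next to the diaryl ether moves this read-out.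

Compound 3 `Cc1cc(/C=C/C#N)cc(Oc2cc(Nc3ncnc(C4CC4)n3)ccc2C)c1` is the not yet measured analogue of compound 1. The difference is methyl in place of chloro on an aromatic carbon. An exchange of one halogen for one carbon on an aromatic carbon, with no change in ring count, donors, acceptors or charge, is expected to move this assay little, most likely by nothing beyond the scatter; the step from compound 1 to compound 3 is estimated at a 1.2-fold higher number from compound 1 to compound 3 (0.09 log units; within the scatter). Compound 3 is accordingly estimated at 2200 nM, with a range from 900 nM to 5500 nM.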

Compound 3, half-maximal cytotoxic concentration: 73 nM
The estimate for compound 3 lay 30-fold (1.48 log units) above the measured number; measured number below the stated range.
By their numbers in this assay, from the lowest: compound 3; then compound 1; then compound 2.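

Methyl in place of chloro on this aromatic carbon, ortho to a large group and para to a large group, is not a neutral exchange in this assay: the single change gives a 25-fold lower number from compound 1 to compound 3 (1.39 log units; beyond the scatter), a step beyond the scatter. The two groups match in everything counted here, with one heavy atom each, no ring, no hydrogen-bond donors or acceptors and no net charge, yet the read-out still moves strongly, so such matching counts do not make this position a safe place for exchange. No measurement at hand bears on why this exchange shifts the read-out so far.

Only chloro and methyl are shown on this carbon, which leaves open whether the lower number is particular to methyl or would also appear with fluoro, methoxy or an amine in the same place. Also open, as far as these compounds go, is whether the same exchange on compound 2, which also carries a chloro group, would give a step of similar size, or whether the effect belongs to the core of compound 1.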